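A few compounds are considered here, and "the series" means these few. Any claim that something is new, unique, unknown or untested is made for them only; others in the source may bear on it.

Compound 3 `CCOc1ccc(Br)cc1C(C)NC(=O)N(C)S(=O)(=O)c1ccccc1` gives 19800 nM in a functional assay on thoracic aorta (Rattus norvegicus, strain Wistar), with a stated time of 15 min (on this read-out lower numbers stand for an effect already at smaller amounts and higher numbers for an effect only at larger amounts of compound), and stands second highest of the three measured numbers. Compound 1 `COc1ccc(Br)cc1C(C)NC(=O)N(C)S(=O)(=O)c1ccccc1` gives 16800 nM and compound 2 `CCOc1ccc(Br)cc1C(C)NC(=O)N(C)S(=O)(=O)c1ccc(C)cc1` gives 28600 nM; both lie within the scatter of compound 3, so no order among the three is claimed. The step to compound 4 `CC(NC(=O)N(C)S(=O)(=O)c1ccccc1)c1cc(Br)ccc1OCc1ccccc1` is phenyl in place of methyl on a saturated chain carbon bound to an oxygen on an aromatic ring. The same place has been varied once before, a 1.2-fold higher number from compound 1 to compound 3 (0.07 log units; within the scatter), a step within the scatter. The other measured step, a 1.4-fold lower number from compound 2 to compound 3 (0.16 log units; within the scatter), concerns a different place and bears less on this change. Within the data shown here, no measured compound carries a group as large as phenyl at this place, so the expectation rests on the small variation seen so far. Compound 4 is therefore expected near compound 3, the estimated step being a 1.0-fold higher number from compound 3 to compound 4 (0.00 log units; within the scatter), with the estimate for compound 4 at 20000 nM and a range from 7000 nM to 60000 nM.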

Compound 4, half-maximal effective concentration: 60300 nM
The estimate for compound 4 lay 3.0-fold (0.48 log units) below the measured number, and the stated range ends below it.
By their numbers in this assay, from the lowest: compounds 1, 3 and 2 (each within the scatter of the next); then compound 4.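

In this assay, among these compounds, phenyl at this place gives the first steps beyond the scatter: a 3.0-fold higher number from compound 3 to compound 4 (0.48 log units; beyond the scatter), and a 3.6-fold higher number from compound 1 to compound 4 (0.56 log units; beyond the scatter). The place therefore does respond to substitution, if only modestly, whereas methyl in place of hydrogen left the number within the scatter. Nothing measured here accounts for the rise.

As far as these compounds go, whether the rise belongs to the aromatic ring or simply to a longer group remains open. Cyclohexyl or a propyl chain in place of phenyl would separate the two, and a pyridyl ring or a carboxylic acid at this place is equally untested in the compounds shown.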